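Swapping the Halogenated Phenyl Chain on a Shared Core

This account rests on a few compounds, and the source may have more. Where it says the series, first, only, none or still open, it means among the compounds named here.

Three measured compounds share one core and differ only in the aryl-ethenyl group attached to the carbonyl carbon. Compound 1 `Cc1ccc(/C=C\C(=O)N2N=C(c3ccncc3)OC2c2c[nH]c3ccccc23)cc1` was tested in an ADME assay on PANC-1 cells (Homo sapiens) for cytotoxicity, read by MTT assay, with a stated time of 48 h (a lower number here means a stronger inhibitor of growth, a higher number a weaker inhibitor of growth), and reached no number, only a limit of > 30 ug/mL. Compound 2 `O=C(/C=C\c1cccc(F)c1)N1N=C(c2ccncc2)OC1c1c[nH]c2ccccc12` likewise gave only a limit in this assay, > 30 ug/mL. Compound 3 `O=C(/C=C/c1c(Cl)cccc1Cl)N1N=C(c2ccncc2)OC1c1c[nH]c2ccccc12` also gave only a limit in this assay, > 30 ug/mL. Compound 3 thus sits at the limit (the limit of > 30 ug/mL in this assay, at which 3 of the 3 values shown sit). The steps a step that the two limits leave unreadable from compound 1 to compound 2, a step that the two limits leave unreadable from compound 1 to compound 3 and a step that the two limits leave unreadable from compound 2 to compound 3 consequently have no readable size.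

Compound 4 `O=C(/C=C\c1cccc(Br)c1)N1N=C(c2ccncc2)OC1c1c[nH]c2ccccc12` is not yet measured. It differs from compound 3 by 2-(3-bromophenyl)ethenyl in place of 2-(2,6-dichlorophenyl)ethenyl on a carbonyl carbon. The measured steps that bear on this change are the three exchanges of one aryl-ethenyl group for another, and every one of them is unreadable, so no step beyond the scatter can be expected in this assay in either direction. Compound 4 is therefore expected to give about 45 ug/mL, within 20 ug/mL to 100 ug/mL, most likely again only as a limit. The expected step that the limit leaves unreadable from compound 3 to compound 4 is close to none.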

Compound 4, concentration for 50% growth inhibition: > 30 ug/mL
Compound 4 was reported as a limit (the forecaster's own chance of this, stated with the estimate: 75%); the middle value lies beyond the limit too.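

Compound 4 also gives only a limit, so its steps from compound 1, compound 2 and compound 3 cannot be read. The compounds shown leave open how these four groups on the shared core would rank in this assay, since all stop at one limit: the limit of > 30 ug/mL in this assay, at which 4 of the 4 values shown sit.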